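This account rests on a few compounds, and the source may have more. Where it says the series, first, only, none or still open, it means among the compounds named here.

Measured so far in an assay on microsomes from liver for inhibition of 3-hydroxy-3-methylglutaryl-coenzyme A reductase (Rattus norvegicus); on this read-out higher numbers stand for weaker inhibition and lower numbers for stronger inhibition: compound 1 `CCN(Cc1ccccc1)C(=O)c1nn(-c2ccc(F)cc2)c(OC[C@@H](O)C[C@@H](O)CC(=O)O)c1C(C)C` gives 14 nM, compound 2 `CC(C)c1c(C(=O)NCc2cccc(F)c2F)nn(-c2ccc(F)cc2)c1OC[C@@H](O)C[C@@H](O)CC(=O)O` gives 2 nM, and compound 3 `CC(C)c1c(C(=O)N(C)Cc2ccc(F)cc2)nn(-c2ccc(F)cc2)c1OC[C@@H](O)C[C@@H](O)CC(=O)O` gives 18 nM.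

On these numbers compound 3 stands highest of the three. Its distance from compound 1, a 1.3-fold higher number from compound 1 to compound 3 (0.11 log units; within the scatter), lies within the scatter, whereas a 9.0-fold higher number from compound 2 to compound 3 (0.95 log units; beyond the scatter) lies beyond it. Compound 4 `CC(C)c1c(C(=O)N(C)[C@H](C)c2ccccc2)nn(-c2ccc(F)cc2)c1OC[C@@H](O)C[C@@H](O)CC(=O)O` differs from compound 3 by 1-phenylethyl in place of 4-fluorobenzyl on an amide-type nitrogen. The step that bears most directly on this exchange is a 1.3-fold higher number from compound 1 to compound 3 (0.11 log units; within the scatter), where the groups on the amide-type nitrogen were also swapped with no effect beyond the scatter. The larger step of a 9.0-fold higher number from compound 2 to compound 3 (0.95 log units; beyond the scatter) replaced a different amino group and is less comparable. Compound 4 is therefore expected to show no change at the digits printed from compound 3 to compound 4 (within the scatter), a change not beyond the scatter. The estimate for compound 4 in this assay is 18 nM, expected to fall between 6 nM and 55 nM.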

Compound 4, half-maximal inhibitory concentration: 21 nM
The estimate for compound 4 lay 1.2-fold (0.07 log units) below the measured number, within the range that was stated.
By their numbers in this assay, from the lowest: compound 2; then compounds 1, 3 and 4 (each within the scatter of the next).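

In this assay, exchanging 4-fluorobenzyl for 1-phenylethyl on the amide-type nitrogen removes the fluorine and adds a defined stereocentre, yet the step stays within the scatter (a 1.2-fold higher number from compound 3 to compound 4 (0.07 log units; within the scatter)). Compound 4 also stays within the scatter of the benzyl(ethyl)amino compound (a 1.5-fold higher number from compound 1 to compound 4 (0.18 log units; within the scatter)), while the step from the 2,3-difluorobenzyl amide is beyond it (an 11-fold higher number from compound 2 to compound 4 (1.02 log units; beyond the scatter)). No evidence given here bears on these results. Still open, as far as these compounds go, is how the mirror-image 1-phenylethyl group would read, and how 2,3-difluorobenzyl would read on a nitrogen also carrying methyl.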